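Methyl on the ring amide nitrogen across two related cores

This account rests on a few compounds, and the source may have more. Where it says the series, first, only, none or still open, it means among the compounds named here.

Four compounds built on closely related cores were compared in a functional assay on HeLa cells (Homo sapiens) for inhibition, read by MTT assay, with a stated time of 48 h; on this read-out lower numbers stand for stronger inhibition and higher numbers for weaker inhibition. Compound 1, with the structure `CN1CCN(c2ccc(Nc3ncc4c(n3)N(C3CCCC3)CC(=O)N4)cc2)CC1`, gives 21300 nM in this assay. Compound 3, with the structure `CN1CCN(c2ccc(Nc3ncc4c(n3)N(C3CCCC3)CC(=O)N4C)cc2)CC1`, differs from compound 1 only by methyl in place of hydrogen on an amide-type nitrogen in a ring. In this assay compound 3 gives 6750 nM. That change produced a 3.2-fold lower number from compound 1 to compound 3 (0.50 log units; beyond the scatter), so the methylated compound 3 is the more potent of the two.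

Compound 2, with the structure `CN1CCN(c2ccc(Nc3ncc4c(n3)N(C3CCCC3)CC(=O)N4)nc2)CC1`, shares the same arrangement of groups but its core differs from that of compound 1; the difference between the two cores is not broken down here. In this assay compound 2 gives only a limit of the assay, > 30000 nM, and not a number. Among the three measured values, the evidence notes (the limit of > 30000 nM in this assay, at which 1 of the 3 values shown sits).

Compound 4, with the structure `CN1CCN(c2ccc(Nc3ncc4c(n3)N(C3CCCC3)CC(=O)N4C)nc2)CC1`, has not yet been measured. Among the compounds with values here, it stands to compound 2 exactly as compound 3 stands to compound 1: the change is methyl in place of hydrogen on an amide-type nitrogen in a ring, the same change, at the same place, as the one between compound 1 and compound 3.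

Since the measured step from compound 1 to compound 3 was a 3.2-fold lower number from compound 1 to compound 3 (0.50 log units; beyond the scatter), a step of similar size is expected from compound 2 to compound 4, namely an at least 1.5-fold lower number from compound 2 to compound 4 (0.17 log units; that floor lies within the scatter), with the caveat that the starting point for compound 2 is itself only a limit. On that basis compound 4 is estimated to give about 20000 nM in this assay, most plausibly between 8000 nM and 60000 nM.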

Compound 4, half-maximal inhibitory concentration: 13100 nM
Estimate against measurement, compound 4: 1.5-fold (0.18 log units) above; the measured number falls inside the stated range.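

In this assay, a methyl in place of hydrogen on the amide-type nitrogen in the ring lowers the number on both cores, and on the core of compound 2 the result is an at least 2.2-fold lower number from compound 2 to compound 4 (0.35 log units; beyond the scatter). Set side by side, the two results read: the same change on two cores in this assay, a 3.2-fold lower number (0.50 log units; beyond the scatter) from compound 1 to compound 3 and an at least 2.2-fold lower number (0.35 log units; beyond the scatter) from compound 2 to compound 4; the limit leaves it open whether they differ. Compound 2 gives > 30000 nM, which is a limit of the assay and not a number, so the two pairs agree in direction, but the size of the step on this core remains only a floor, and nothing shows that the change has the same size on both cores.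

The compounds shown carry only hydrogen or methyl on this nitrogen, so they leave open whether a longer chain such as ethyl, or a chain ending in an amine or a carboxylic acid, would move the number the same way. Going by these compounds, all of them also keep the cyclopentyl group, so it remains open whether the step would hold with a cyclopropyl group there, or on any core beyond these two.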